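The source may hold more compounds than are shown below. What is called first, only, known or untested is meant among the compounds shown, and "the series" means these compounds.

Working notes on the series in a functional assay (Oryctolagus cuniculus) for inhibition of platelet-activating factor receptor (Cavia porcellus); on this read-out lower numbers stand for stronger inhibition and higher numbers for weaker inhibition.

Within the data shown here, compound 2 `CCCC(C)NC(=O)OCC1CN(C(=O)c2cc(OC)c(OC)c(OC)c2)CCN1C(=O)c1cc(OC)c(OC)c(OC)c1` holds the lowest of the two numbers measured so far: in this assay compound 2 gives 100 nM. Among the measured compounds shown here, the only other measured member is compound 1 `COc1cc(C(=O)N2CCN(C(=O)c3cc(OC)c(OC)c(OC)c3)C(COC(=O)C3CCCCC3)C2)cc(OC)c1OC`, which in this assay gives 290 nM; the single step between them, a 2.9-fold lower number from compound 1 to compound 2 (0.46 log units; beyond the scatter), is the one piece of structure-activity information available.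

Compound 3 `CCC(C)CNC(=O)OCC1CN(C(=O)c2cc(OC)c(OC)c(OC)c2)CCN1C(=O)c1cc(OC)c(OC)c(OC)c1` is the next member to be measured. It differs from compound 2 by 2-methylbutyl in place of 1-methylbutyl on an amide-type nitrogen. For the measured compounds named here, no measured step bears directly on this change: the step from compound 1 to compound 2 swaps a cyclohexyl for a (1-methylbutyl)amino group, whereas here the two structures have the same atoms, joined differently, and only the branching of the five-carbon chain moves. There is therefore no basis in the data for predicting a shift beyond the scatter in either direction.

For compound 3 the expectation in this assay is 120 nM, with a range of 50 nM to 300 nM, which corresponds to an estimated step of a 1.2-fold higher number from compound 2 to compound 3 (0.08 log units; within the scatter) from compound 2.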

Compound 3, half-maximal inhibitory concentration: 470 nM
Compound 3: the middle estimate sits 3.9-fold (0.59 log units) below what was measured; measured number above the stated range.
By their numbers in this assay, from the lowest: compound 2; then compounds 1 and 3 (each within the scatter of the next).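

In this assay, the branching of the five-carbon chain on the amide-type nitrogen is enough on its own to move the number: 2-methylbutyl in place of 1-methylbutyl gives a 4.7-fold higher number from compound 2 to compound 3 (0.67 log units; beyond the scatter) with the same atoms joined differently, so this position distinguishes between two isomeric chains. The gain seen with the (1-methylbutyl)amino group therefore does not extend to its isomer, as the (2-methylbutyl)amino group gives only a 1.6-fold higher number from compound 1 to compound 3 (0.21 log units; within the scatter) and leaves compound 3 and compound 1 within the scatter of each other. No available evidence accounts for this difference between the two chains.

Open, on these data alone, is whether the lower number of compound 2 depends specifically on the 1-methylbutyl arrangement or would also appear with other chains on the same nitrogen, such as an unbranched pentyl or a 1-ethylpropyl group. Also open, as far as these compounds go, is how a shorter chain such as isopropyl, or a cyclic group such as cyclopentyl, would read at this position.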